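This account rests on a few compounds, and the source may have more. Where it says the series, first, only, none or still open, it means among the compounds named here.

The measured compounds, with their values in a functional assay on CCRF-CEM cells (Homo sapiens) for cytotoxicity; a higher number here means that more compound is tolerated, a lower number that less compound is tolerated:

Compound 1 `CN(C)c1ncnc2c(Cc3ccccc3)ncn12` gives > 790000 nM.
Compound 2 `Cc1ccc(Cc2ncn3c(N(C)C)ncnc23)cc1` gives 412000 nM.
Compound 3 `CSC1N=CNc2c(C)ncn21` gives 176000 nM.

The value of compound 1, > 790000 nM, is a limit of this assay, not a number (the limit of > 790000 nM in this assay, at which 1 of the 3 values shown sits). Compound 2 differs from compound 1 by methyl in place of hydrogen on an aromatic carbon, and this assay shows an at least 1.9-fold lower number from compound 1 to compound 2 (0.28 log units; that floor lies within the scatter). Compound 3 has a different core from compound 1; the difference between the two cores is not broken down here. Compound 4 `CSC1N=CNc2c(C)nc(C)n21` is not yet measured and differs from compound 3 by methyl in place of hydrogen on an aromatic carbon. Within the data shown here, this is the same kind of change as the one from compound 1 to compound 2, but not the same: in compound 2 the methyl sits on a six-membered aromatic ring of carbon only, para to a large group, whereas in compound 4 it sits on a five-membered aromatic ring with 2 nitrogen, between two ring nitrogen atoms. From compound 3 to compound 4 the expected step is a 1.5-fold lower number from compound 3 to compound 4 (0.17 log units; within the scatter), resting on the earlier step of an at least 1.9-fold lower number from compound 1 to compound 2 (0.28 log units; that floor lies within the scatter), whose floor lies within the scatter. Compound 4 is therefore estimated at 120000 nM, with a range from 40000 nM to 350000 nM.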

Compound 4, half-maximal cytotoxic concentration: 440000 nM
Beside the measured number, compound 4's estimate is 3.7-fold (0.56 log units) below it, outside the stated range (above it).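

In this assay, placing a methyl in place of hydrogen on the aromatic carbon between two ring nitrogen atoms gives a 2.5-fold higher number from compound 3 to compound 4 (0.40 log units; beyond the scatter), so the size and direction of this change on one core cannot simply be carried over to the other: the same change on two cores in this assay, an at least 1.9-fold lower number (0.28 log units; that floor lies within the scatter) from compound 1 to compound 2 and a 2.5-fold higher number (0.40 log units; beyond the scatter) from compound 3 to compound 4, at least 4.7-fold (0.68 log units) apart, beyond the scatter of two such steps. Compound 1 stands at a limit of the assay, not at a number, so the earlier step is known only as a floor: the limit of > 790000 nM in this assay, at which 1 of the 4 values shown sits. With one pair on each core, and the methyl on a different kind of ring in each pair, these results do not show why the two steps differ or what the same change would do on any further core.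

As far as these compounds go, it remains open whether a group larger than methyl on that same carbon, such as ethyl or a longer chain, would shift the number further. An amine or a carboxylic acid at that place on the core of compound 3 is also left open.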